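The compounds below may be only part of what the source reports. "The series", "measured", "known", "first", "only" and "open" are said of these compounds alone.

In a functional assay on trachea (Rattus norvegicus, strain Wistar), with a stated time of 15 min (on this read-out higher numbers stand for an effect only at larger amounts of compound and lower numbers for an effect already at smaller amounts), compound 1 `CC(NC(=O)NS(=O)(=O)c1ccc(Cl)cc1)c1cc(Br)ccc1OCc1ccccc1` gives 30800 nM as its reading. Compound 2 `COc1ccc(Br)cc1C(C)NC(=O)N(C)S(=O)(=O)c1ccc(C)cc1` reads 12800 nM and holds the lower of the two numbers, by a gap beyond the usual scatter. A lower number here means an effect already at smaller amounts of compound. The two compounds differ in more than one place, so their gap cannot be tied to any single change. Compound 3 `COc1ccc(Br)cc1C(C)NC(=O)N(C)S(=O)(=O)c1ccc(Cl)cc1` has yet to be measured and differs from compound 2 in one place chloro in place of methyl on an aromatic carbon with chloro in place of methyl on an aromatic carbon, para to a large group. Going by the values given here, no measured pair shows this swap, so in this assay only a small step is expected, none beyond the scatter and in no firm direction. The estimated step of a 1.1-fold lower number from compound 2 to compound 3 (0.03 log units; within the scatter) is therefore slight. For compound 3 the expected value is 12000 nM with an estimated range from 4500 nM to 30000 nM in this measurement.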

Compound 3, half-maximal effective concentration: 39300 nM
Compound 3: middle estimate off by 3.3-fold (0.52 log units), on the low side; the whole stated range lies below it.
By their numbers in this assay, from the lowest: compound 2; then compounds 1 and 3 (each within the scatter of the next).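

In this assay, swapping 4-methylphenyl for 4-chlorophenyl gives a 3.1-fold higher number from compound 2 to compound 3 (0.49 log units; beyond the scatter) and so means that a larger amount of compound is needed for the effect. Going by these compounds alone, this is the first comparison in the set with only one place changed, and it shows that exchanging a single heavy atom at this position, para to a large group, can move the reading beyond the usual scatter, even with no change in the count of hydrogen-bond donors or acceptors. No measurement here explains the step.

On these data alone, with only methyl and chloro read at this position, it remains open how an amine or a carboxylic acid there would compare. As far as these compounds go, it is also open whether the same swap would give a similar step on the core of compound 1.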